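This account rests on a few compounds, and the source may have more. Where it says the series, first, only, none or still open, it means among the compounds named here.

Compound 1 `COc1ccc(OS(=O)(=O)c2ccc(N3CCN(C)C3=O)cc2)cc1` and compound 2 `CN1CCN(c2ccc(S(=O)(=O)Oc3ccc(F)cc3)cc2)C1=O` share one core and differ by fluoro in place of methoxy on an aromatic carbon. In a functional assay on M21 cells (Homo sapiens) for antiproliferative activity, read by sulforhodamine B assay, with a stated time of 48 h (a lower number here means a stronger inhibitor, a higher number a weaker inhibitor), compound 1 gives > 100000 nM, which is a limit of the assay and not a number. Compound 2 likewise gives > 100000 nM, again a limit rather than a number. The step that the two limits leave unreadable from compound 1 to compound 2 therefore cannot be sized because of the limit of > 100000 nM in this assay, at which 2 of the 3 values shown sit. Compound 3 `CCCCN1CCN(c2ccc(S(=O)(=O)Oc3cccc(OC)c3)cc2)C1=O` carries a different core; the difference between the two cores is not broken down here. In this assay compound 3 gives 30000 nM. Compound 4 `CCCCN1CCN(c2ccc(S(=O)(=O)Oc3cccc(F)c3)cc2)C1=O` is not yet measured and differs from compound 3 by fluoro in place of methoxy on an aromatic carbon; since the group sits meta to a large group rather than para to a large group, this is the same kind of change, not the same. Because compound 3 gives 30000 nM and the earlier step of this kind is unreadable, compound 4 is expected to show a step of a 1.3-fold higher number from compound 3 to compound 4 (0.12 log units; within the scatter). Compound 4 is estimated at 40000 nM, between 12000 nM and 150000 nM.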

Compound 4, half-maximal inhibitory concentration: > 100000 nM
Compound 4: only a limit was reported (the forecaster's own chance of this, stated with the estimate: 35%); middle value at least 2.5-fold (0.39 log units) away from the limit.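

In this assay, fluoro in place of methoxy on the second core gives an at least 3.3-fold higher number from compound 3 to compound 4 (0.52 log units; beyond the scatter), a step beyond the usual scatter. The value of compound 4, > 100000 nM, is a limit of the assay and not a number. The same change on the core of compound 1 cannot be read, so nothing here shows whether the change carries from one core to the other, and the reason lies in this: the limit of > 100000 nM in this assay, at which 3 of the 4 values shown sit.

The compounds shown leave open how an amine or a carboxylic acid would fare in place of methoxy on that aromatic carbon. They also leave open how a longer chain on the core would read in this assay.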